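From tert-butyl to methoxycarbonyl: an expected shift in cytotoxicity

This account rests on a few compounds, and the source may have more. Where it says the series, first, only, none or still open, it means among the compounds named here.

For the measured compounds named here, in an ADME assay on L6 cells (Rattus norvegicus) for cytotoxicity, read by resazurin assay, with a stated time of 72 h (a lower number here means a stronger inhibitor, a higher number a weaker inhibitor), compound 2 `CC(C)(C)c1ccc(C(=O)NC(=O)c2ccccc2O)cc1` gives 2.3 ug/mL, the lowest of the three numbers measured so far. Compound 1 `Cc1occc1C(=O)NC(=O)c1ccccc1O` gives 16 ug/mL, and compound 3 `O=C(NC(=O)c1ccccc1O)c1ccc([N+](=O)[O-])cc1` gives 53 ug/mL. Going by the values given here, the only measured step at the same position is a 23-fold higher number from compound 2 to compound 3 (1.36 log units; beyond the scatter), a large step beyond the scatter. Compound 4 `COC(=O)c1ccc(C(=O)NC(=O)c2ccccc2O)cc1` differs from compound 2 as methoxycarbonyl in place of tert-butyl on an aromatic carbon. Because a 23-fold higher number from compound 2 to compound 3 (1.36 log units; beyond the scatter) rose steeply when the tert-butyl was replaced at that position, compound 4 is expected to show a higher number than compound 2 in this assay, though the size of that step is uncertain with a single precedent. Compound 4 is therefore estimated at 15 ug/mL, between 5 ug/mL and 45 ug/mL, an expected 6.5-fold higher number from compound 2 to compound 4 (0.81 log units; beyond the scatter).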

Compound 4, half-maximal inhibitory concentration: 42 ug/mL
Beside the measured number, compound 4's estimate is 2.8-fold (0.45 log units) below it, within the range that was stated.
By their numbers in this assay, from the lowest: compound 2; then compound 1; then compounds 4 and 3 (each within the scatter of the next).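

In this assay the change to methoxycarbonyl gives an 18-fold higher number from compound 2 to compound 4 (1.26 log units; beyond the scatter) and so repeats the large rise seen on leaving tert-butyl at this position. Methoxycarbonyl in place of nitro gives a 1.3-fold lower number from compound 3 to compound 4 (0.10 log units; within the scatter) and leaves these two replacements indistinguishable here, with compound 2 well apart from both. Nothing measured here accounts for this gap.

Going by these compounds, whether any replacement of tert-butyl at this position stays near compound 2 remains open. An amine or a carboxylic acid there could fall near compound 2 or alongside compound 3 and compound 4, and a longer alkyl chain is equally undecided.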